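One Methyl Added: Expecting Little Change in Potency

The source may hold more compounds than are shown below. What is called first, only, known or untested is meant among the compounds shown, and "the series" means these compounds.

Compound 1 `Cc1cc(=O)oc2cc(Sc3cccc(Cl)n3)ccc12`: 1480 nM
Compound 2 `O=c1ccc2ccc(Oc3no[n+]([O-])c3S(=O)(=O)c3ccccc3)cc2o1`: 4550 nM

In a functional assay on HeLa cells (Homo sapiens) for antiproliferative activity, read by MTT assay, with a stated time of 48 h (a lower number here means a stronger inhibitor, a higher number a weaker inhibitor), compound 1 gives 1480 nM, while compound 2 gives 4550 nM, the higher of the two numbers and thus the weaker inhibitor, a gap beyond the scatter. Compound 3 `Cc1cc(=O)oc2cc(Oc3no[n+]([O-])c3S(=O)(=O)c3ccccc3)ccc12` differs from compound 2 by methyl in place of hydrogen on an aromatic carbon. Among the compounds with values here, no measured pair shows what this methyl alone does; compound 1 carries it, but its other group differs as well. A single added carbon is expected to shift the number little, if at all, beyond the scatter. Compound 3 is estimated at 3500 nM, ranging from 1500 nM to 8000 nM. The expected step is a 1.3-fold lower number from compound 2 to compound 3 (0.11 log units; within the scatter).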

Compound 3, half-maximal inhibitory concentration: > 20000 nM
Compound 3: no number, only a limit (the forecaster's own chance of this, stated with the estimate: 5%); at least 5.7-fold (0.75 log units) between middle value and limit.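

In this assay, placing a methyl on this aromatic carbon, opposite the ring oxygen, gives an at least 4.3-fold higher number from compound 2 to compound 3 (0.64 log units; beyond the scatter). So in this pair, one added carbon at this position weakens the compound beyond the scatter, and the position is not indifferent to change. Compound 3 gives no exact number, only a limit, so the full size of the loss stays unknown: the limit of > 20000 nM in this assay, at which 1 of the 3 values shown sits.

Still open, on these data alone, is how a longer chain, such as ethyl, or an amine would behave on this carbon. Also open, as far as these compounds go, is whether this methyl has the same effect when the rest of the molecule differs.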